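The source may report more compounds than this note shows. Statements on the series, on what has been measured and on what is new or still open speak of the compounds shown alone.

Compound 1 `Clc1ccccc1-n1cc(CSc2nc3ccccc3s2)nn1` gives 83.3% in a functional assay on the whole organism (strain Albino Wistar) for inhibition, with Rattus norvegicus as the target, read by paw edema, with stated times of 1 h and 3 h, at a dose of 10 mg/kg by the oral route; a lower number here means less inhibition, a higher number more inhibition at the dose given (going by the name of the read-out).
Compound 2 `c1ccc(-n2cc(CSc3nc4ccccc4s3)nn2)cc1` gives 46.7% in this assay.
Compound 3 `CC1(C)OCC(Cn2cc(CSc3nc4ccccc4s3)nn2)O1` gives 53.3% in this assay.

Among these three numbers compound 3 stands second highest: its nearest neighbour is compound 2, a gap within the usual scatter, while compound 1 lies well beyond it, as the step of a number 30 percentage points lower from compound 1 to compound 3 (beyond the scatter) shows. Compound 4 `OCC(O)Cn1cc(CSc2nc3ccccc3s2)nn1` shares the core with compound 3 and differs in one place: 1,2-dihydroxyethyl in place of 2,2-dimethyl-1,3-dioxolan-4-yl on a saturated chain carbon bound to an aromatic nitrogen.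

Among the measured compounds shown here, no measured step opens the five-membered ring in this way, so no step bears on the change directly. What the measured steps do show is that the part attached to the aromatic nitrogen matters: the step of a number 36.6 percentage points lower from compound 1 to compound 2 (beyond the scatter) and the step of a number 30 percentage points lower from compound 1 to compound 3 (beyond the scatter) are both large drops from compound 1, whereas the step of a number 6.6 percentage points higher from compound 2 to compound 3 (within the scatter) stays within the scatter. For the smaller change from compound 3 to compound 4, a step within the scatter is therefore expected, as a number 3.3 percentage points lower from compound 3 to compound 4 (within the scatter). Compound 4 is estimated to give 50% in this assay, expected to lie between 33% and 67%.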

Compound 4, a percentage reported as inhibition, in the whole organism at one dose (the size of the read-out at that dose, not a potency): 56.7%
The estimate for compound 4 lay 6.7 percentage points below the measured number; measured number inside the range.
By their numbers in this assay, from the lowest: compounds 2, 3 and 4 (each within the scatter of the next); then compound 1.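

Opening the 2,2-dimethyl-1,3-dioxolan-4-yl ring to 1,2-dihydroxyethyl removes the ring and adds 2 hydrogen-bond donors, yet the step in this assay is only a number 3.4 percentage points higher from compound 3 to compound 4 (within the scatter) and so cannot separate the closed ring from the open chain at this place, on a saturated chain carbon bound to an aromatic nitrogen. Set against phenyl, the 2,3-dihydroxypropyl group gives a number 10 percentage points higher from compound 2 to compound 4 (within the scatter) and so cannot be told apart from it either, whereas replacing 2-chlorophenyl with the same group gives a number 26.6 percentage points lower from compound 1 to compound 4 (beyond the scatter) and leaves compound 1 as the only one of the four that stands clear of the others. Nothing measured here explains why such different groups cannot be separated or why compound 1 stands apart.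

The compounds shown leave open whether an amine or a carboxylic acid on this chain, or a longer chain carrying the two hydroxyl groups, would shift the number. They also leave open whether a bromo or methyl group in place of the chloro of compound 1 would hold its high number.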